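A few compounds are considered here, and "the series" means these few. Any claim that something is new, unique, unknown or untested is made for them only; others in the source may bear on it.

Measured so far:
- compound 1 `Cc1cc(C2CCC2)c(S(C)(=O)=O)cc1C(=O)N=C(N)N`: 8.2 nM in a functional assay for inhibition of sodium/hydrogen exchanger (Oryctolagus cuniculus); on this read-out lower numbers stand for stronger inhibition and higher numbers for weaker inhibition
- compound 2 `Cc1cc(-c2cc(Cl)cc(Cl)c2)c(S(C)(=O)=O)cc1C(=O)N=C(N)N`: 130 nM in this assay

For the measured compounds named here, of these two, compound 2 shows the higher number, and the only measured step touching it is a 16-fold higher number from compound 1 to compound 2 (1.20 log units; beyond the scatter), where a 3,5-dichlorophenyl group replaced a cyclobutyl group. Compound 3 `CCSc1cc(C)c(C(=O)N=C(N)N)cc1S(C)(=O)=O` differs from compound 2 at the same position: ethylsulfanyl in place of 3,5-dichlorophenyl on an aromatic carbon. Going by the values given here, the one measured step indicates that the ring-bearing dichlorophenyl group goes with a much higher number than the smaller cyclobutyl group did. Among the compounds with values here, the ethylsulfanyl group has fewer atoms and no ring, as the counted difference shows, so the change is expected to move the number back down, by a step roughly of the size seen when the cyclobutyl was exchanged, although no direct precedent for this exact group exists. Compound 3 is therefore expected to give about 15 nM in this assay, within a range of 4 nM to 60 nM. The expected step of an 8.7-fold lower number from compound 2 to compound 3 (0.94 log units; beyond the scatter) rests on a single comparison and is correspondingly uncertain.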

Compound 3, half-maximal inhibitory concentration: 5.9 nM
Beside the measured number, compound 3's estimate is 2.5-fold (0.41 log units) above it; measured number inside the range.
By their numbers in this assay, from the lowest: compounds 3 and 1 (each within the scatter of the next); then compound 2.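

Replacing 3,5-dichlorophenyl with ethylsulfanyl gives a 22-fold lower number from compound 2 to compound 3 (1.34 log units; beyond the scatter) in this assay, so the high number of compound 2 belongs to that particular group and not to this position in general. Exchanging cyclobutyl for ethylsulfanyl gives a 1.4-fold lower number from compound 1 to compound 3 (0.14 log units; within the scatter), so these two groups cannot be told apart in this read-out, and a low number at this position does not need a ring. Nothing available explains why 3,5-dichlorophenyl stands apart from the other two groups.

The compounds shown leave open whether the high number goes with the aromatic ring itself or with its two chlorines, a question that a plain phenyl group would address. They also leave open how far the chain can grow, as with butylsulfanyl, and whether a methoxy group or an amine at this position would keep the number low.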